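A few compounds are considered here, and "the series" means these few. Any claim that something is new, unique, unknown or untested is made for them only; others in the source may bear on it.

Going by the values given here, compound 2 `CCCCCOC(=O)Cc1c(C(C)C)nc(CCCC)n(Cc2ccc(-c3ccccc3-c3noc(=O)[nH]3)cc2)c1=O` gives 19.7% in an ADME assay on microsomes from liver (Mus musculus) for metabolic stability, with a stated time of 30 min (a higher number here means that more of the compound is left, a lower number that less of the compound is left), the higher of the two numbers known so far. Compound 1 `CCCCc1nc(C(C)C)c(CC(=O)OC)c(=O)n1Cc1ccc(-c2ccccc2-c2noc(=O)[nH]2)cc1` gives 9.4% in this assay. The change on the oxygen next to a carbonyl group has been measured once: a number 10.3 percentage points higher from compound 1 to compound 2 (beyond the scatter). Compound 3 `CCCCc1nc(C(C)C)c(CC(=O)OC2CC2)c(=O)n1Cc1ccc(-c2ccccc2-c2noc(=O)[nH]2)cc1` carries cyclopropyl in place of pentyl on an oxygen next to a carbonyl group. Because a number 10.3 percentage points higher from compound 1 to compound 2 (beyond the scatter) arose on that same oxygen, and compound 3 moves part of the way back toward compound 1 there, a downward step of comparable size is expected, a number 7.7 percentage points lower from compound 2 to compound 3 (within the scatter). Compound 3 is therefore estimated at 12%, with a range from 4% to 24%.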

Compound 3, percent of the compound remaining: 11.4%
Estimate against measurement, compound 3: 0.6 percentage points above; the range from low to high includes it.
By their numbers in this assay, from the lowest: compounds 1, 3 and 2 (each within the scatter of the next, the first and the last beyond it).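

With cyclopropyl on the oxygen next to a carbonyl group, this assay shows a number 8.3 percentage points lower from compound 2 to compound 3 (within the scatter) and a number 2 percentage points higher from compound 1 to compound 3 (within the scatter). Compound 3 therefore cannot be separated from either of the other two, even though compound 1 and compound 2 lie beyond the scatter of each other, so this small ring gives no clear reading of its own. No measurement at hand explains these numbers. Still open, from the compounds shown here alone, is how a longer chain such as octyl, or a branched group such as tert-butyl, on that oxygen would compare with compound 2.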